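A few compounds are considered here, and "the series" means these few. Any claim that something is new, unique, unknown or untested is made for them only; others in the source may bear on it.

Working notes on the series. Compound 1 `CC(C)(C)[C@@H](N)C(=O)N1CCN(CCCOc2ccc(C(=O)C3CC3)cc2)CC1`, compound 2 `CC(C)N[C@H](C)C(=O)N1CCN(CCCOc2ccc(C(=O)C3CC3)cc2)CC1` and compound 3 `CCC[C@@H](N)C(=O)N1CCN(CCCOc2ccc(C(=O)C3CC3)cc2)CC1` share one core and differ only in the group on the amide carbonyl carbon. In an assay for binding affinity to histamine H2 receptor (Homo sapiens) (a higher number here means a weaker inhibitor, a lower number a stronger inhibitor), compound 1 gives 19100 nM, compound 2 gives 50100 nM and compound 3 gives 60300 nM. Compound 3 therefore carries the highest of the three numbers, though only one gap is real: a 3.2-fold higher number from compound 1 to compound 3 (0.50 log units; beyond the scatter), whereas a 1.2-fold higher number from compound 2 to compound 3 (0.08 log units; within the scatter).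

Compound 4 `CN[C@@H](C(=O)N1CCN(CCCOc2ccc(C(=O)C3CC3)cc2)CC1)C(C)C` is not yet measured. It differs from compound 3 by 2-methyl-1-(methylamino)propyl in place of 1-aminobutyl on a carbonyl carbon. Going by the values given here, two measured steps bear on this. Tert-butyl to propyl on the chain carbon gave a 3.2-fold higher number from compound 1 to compound 3 (0.50 log units; beyond the scatter), so the 2-methyl branch entering here points toward a lower number. Putting isopropyl on the amine nitrogen while shrinking the side chain gave a 2.6-fold higher number from compound 1 to compound 2 (0.42 log units; beyond the scatter), so the methyl on the nitrogen may cost part of that gain. Compound 4 is therefore expected to sit between compound 1 and compound 3, a modest step down: a 2.0-fold lower number from compound 3 to compound 4 (0.30 log units; within the scatter). The estimate for compound 4 in this assay is 30000 nM, with a range of 10000 nM to 90000 nM.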

Compound 4, inhibition constant: 49000 nM
Compound 4: middle estimate off by 1.6-fold (0.21 log units), on the low side; low and high end bracket the measured number.
By their numbers in this assay, from the lowest: compound 1; then compounds 4, 2 and 3 (each within the scatter of the next).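

The change from 1-aminobutyl to 2-methyl-1-(methylamino)propyl on a carbonyl carbon has no readable effect (a 1.2-fold lower number from compound 3 to compound 4 (0.09 log units; within the scatter)), and compound 4 also stays level with the 1-(isopropylamino)ethyl analogue (a 1.0-fold lower number from compound 2 to compound 4 (0.01 log units; within the scatter)). Compound 1, with 1-amino-2,2-dimethylpropyl, remains apart from compound 4 (a 2.6-fold higher number from compound 1 to compound 4 (0.41 log units; beyond the scatter)), so a 2-methyl branch with a methyl on the amine nitrogen does not reproduce the number of compound 1, and compounds 2, 3 and 4 now form one level group. No supporting data on hand bear on this result.

The compounds shown do not separate the effect of the chain from that of the amine nitrogen, since none pairs 1-amino-2-methylpropyl, with its unsubstituted amine, with compound 4, or a methylamino group with the tert-butyl chain of compound 1. On these data alone, how a longer chain or a carboxylic acid would read at this carbon also remains open.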